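The compounds below may be only part of what the source reports. "The series", "measured", "known", "first", "only" and "open" are said of these compounds alone.

Compounds measured so far in a functional assay on HCT-116 cells (Homo sapiens) for cytotoxicity, read by MTT assay, with a stated time of 72 h; on this read-out lower numbers stand for stronger inhibition and higher numbers for weaker inhibition:
compound 1, `NS(=O)(=O)c1cc(-c2nnc(/C=C/c3ccccc3)o2)c(Cl)cc1SCc1ccccc1`, gives 18000 nM
compound 2, `NS(=O)(=O)c1cc(-c2nnc(/C=C/c3ccc(Cl)cc3)o2)c(Cl)cc1SCc1ccccc1`, gives 12000 nM

Going by the values given here, compound 2 has the lowest of the two numbers, but the only step separating it from compound 1, a 1.5-fold lower number from compound 1 to compound 2 (0.18 log units; within the scatter), is within the scatter, so the two cannot be ordered.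

Compound 3, `NS(=O)(=O)c1cc(-c2nnc(/C=C/c3c(Cl)cccc3Cl)o2)c(Cl)cc1SCc1ccccc1`, is not yet measured. It differs from compound 2 in one place: 2,6-dichlorophenyl in place of 4-chlorophenyl on a double-bonded chain carbon bound to a double-bonded chain carbon. The same difference, cut one bond further out, reads 2-(4-chlorophenyl)ethenyl to 2-(2,6-dichlorophenyl)ethenyl.

Among the compounds with values here, one measured step bears on this change, the addition of chloro to an aromatic carbon from compound 1 to compound 2, which stayed within the scatter. The change to compound 3 again alters only the chlorine count and arrangement on that ring; nothing measured points to a movement in this assay beyond the scatter in either direction. For compound 3 a step of about no change at the digits printed from compound 2 to compound 3 (within the scatter) is therefore expected, essentially no change. The number for compound 3 is estimated at 12000 nM, with a range from 5000 nM to 30000 nM.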

Compound 3, half-maximal inhibitory concentration: 32000 nM
Compound 3: the middle estimate sits 2.7-fold (0.43 log units) below what was measured, outside the stated range (above it).
By their numbers in this assay, from the lowest: compounds 2, 1 and 3 (each within the scatter of the next, the first and the last beyond it).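

In this assay, the aryl group on the double-bonded chain carbon now shows a change beyond the scatter, which the addition of chloro from compound 1 to compound 2 did not: 2,6-dichlorophenyl in place of 4-chlorophenyl gives (a 2.7-fold higher number from compound 2 to compound 3 (0.43 log units; beyond the scatter)), a modest step. The same 2,6-dichlorophenyl group in place of phenyl stays within the scatter (a 1.8-fold higher number from compound 1 to compound 3 (0.25 log units; within the scatter)), so the readable difference at this position holds only against the 4-chlorophenyl group of compound 2 and does not separate compound 3 from compound 1. No measurement is available here that accounts for this difference between the two comparisons.

Open, as far as these compounds go, is whether a group other than chlorine on this phenyl ring, such as methoxy, an amine or a carboxylic acid, would move the number beyond the scatter in either direction. Going by these compounds alone, also open is whether any change at this position or elsewhere on the shared core gives a number in this assay clearly lower than the one compound 2 gives (12000 nM).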